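The compounds below may be only part of what the source reports. "The series", "measured", "known", "first", "only" and "open" are said of these compounds alone.

Compound 1 `Cc1cc(N)c2cc(NC(=O)/C=C/c3ccc(C(F)(F)F)cc3)ccc2n1` and compound 2 `CCc1cc(N)c2cc(NC(=O)/C=C/c3ccc(C(F)(F)F)cc3)ccc2n1` share one core; compound 2 carries ethyl where compound 1 carries methyl. In a functional assay on HEK293 cells for activation of melanin-concentrating hormone receptor 1 (Homo sapiens), read by inositol phosphate accumulation (on this read-out higher numbers stand for an effect only at larger amounts of compound and lower numbers for an effect already at smaller amounts), compound 1 gives 140 nM and compound 2 gives 110 nM; the step of a 1.3-fold lower number from compound 1 to compound 2 (0.10 log units; within the scatter) is within the scatter, so the two compounds are not separated on this read-out. Compound 3 `CC(C)c1cc(N)c2cc(NC(=O)/C=C/c3ccc(C(F)(F)F)cc3)ccc2n1` continues the same chain: methyl in place of hydrogen on a saturated chain carbon bound to an aromatic carbon and a saturated chain carbon, read one bond further out as ethyl to isopropyl. Among the compounds with values here, only the step from compound 1 to compound 2 bears on it, and it was small, so the step of a 1.1-fold lower number from compound 2 to compound 3 (0.04 log units; within the scatter) is expected to stay within the scatter. Compound 3 is estimated at 100 nM, range 40 nM to 250 nM.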

Compound 3, half-maximal effective concentration: 160 nM
Estimate against measurement, compound 3: 1.6-fold (0.20 log units) below; low and high end bracket the measured number.
By their numbers in this assay, from the lowest: compounds 2, 1 and 3 (each within the scatter of the next).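

In this assay the branched isopropyl shows a 1.5-fold higher number from compound 2 to compound 3 (0.16 log units; within the scatter) and a 1.1-fold higher number from compound 1 to compound 3 (0.06 log units; within the scatter) and so stays within the scatter of both unbranched groups. Methyl, ethyl and isopropyl on this aromatic carbon are therefore not separated, and branching at the saturated chain carbon bound to it brings no readable change in these compounds. Nothing available explains this flat result. Open, going by these compounds, is whether a longer chain such as butyl, a cyclopropyl ring or an amine here would move the number beyond the scatter. The compounds shown also leave open whether the flat result holds with other groups elsewhere on the shared core.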